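The source may hold more compounds than are shown below. What is called first, only, known or untested is meant among the compounds shown, and "the series" means these compounds.

In an assay on LNCaP cells for inhibition of RAC-alpha serine/threonine-protein kinase (Homo sapiens) (a higher number here means a weaker inhibitor, a lower number a stronger inhibitor), compound 1 `CCOCCN(C[C@@H](O)CN1CCCC2(CCN(c3ncncc3C3CC3)C2)C1)S(=O)(=O)c1c(C)cccc1C` gives 740 nM, and compound 2 `Nc1ncnc(N2CC[C@@]3(CCCN(C[C@H](O)CNS(=O)(=O)c4ccccc4Br)C3)C2)c1C1CC1` gives 2000 nM, the higher of the two numbers, the gap to compound 1 lying beyond the usual scatter. Compound 3 `Cc1noc(C)c1S(=O)(=O)NC[C@@H](O)CN1CCC[C@@]2(CCN(c3ncnc(N)c3C3CC3)C2)C1` differs from compound 2 in one place: 3,5-dimethyl-1,2-oxazol-4-yl in place of 2-bromophenyl on a sulfonyl sulfur. Among the measured compounds shown here, no measured pair shows the effect of such an exchange on a sulfonyl sulfur, so the direction of the step is open. Compound 3 is expected to stay close to compound 2, with the estimated step of a 1.3-fold lower number from compound 2 to compound 3 (0.12 log units; within the scatter) not clearly beyond the scatter. Compound 3 is therefore estimated at 1500 nM, within 500 nM to 5000 nM.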

Compound 3, half-maximal inhibitory concentration: 490 nM
Compound 3: middle estimate off by 3.1-fold (0.49 log units), on the high side; measured number below the stated range.
By their numbers in this assay, from the lowest: compounds 3 and 1 (each within the scatter of the next); then compound 2.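

In this assay the exchange of 2-bromophenyl for 3,5-dimethyl-1,2-oxazol-4-yl on a sulfonyl sulfur gives a 4.1-fold lower number from compound 2 to compound 3 (0.61 log units; beyond the scatter) and so shows that the number responds to the group at this position. Both groups have 7 heavy atoms, but only the entering group has hydrogen-bond acceptors, 2 in all. Nothing at hand accounts for the step.

On these data alone, it remains open whether the methyl groups of the entering ring matter, and how an unsubstituted phenyl, a pyridine or an aliphatic amine would fare on the same sulfur.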